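The source may report more compounds than this note shows. Statements on the series, on what has been measured and on what is new or still open speak of the compounds shown alone.

Compound 1, `CCCCCCNc1nc(SCc2ccc(C(F)(F)F)cc2)nc2ccccc12`, gives 23900 nM in a functional assay on HGC-27 cells (Homo sapiens) for cytotoxicity, read by MTT assay, with a stated time of 72 h; a lower number here means a stronger inhibitor, a higher number a weaker inhibitor.
Compound 2, `FC(F)(F)c1ccc(CSc2nc(N3CCCCC3)c3ccccc3n2)cc1`, reaches only a limit of this assay : > 50000 nM.
Compound 3, `COc1ccccc1Nc1nc(SCc2ccc(C(F)(F)F)cc2)nc2ccccc12`, likewise sits at a limit of this assay : > 50000 nM.

Among the measured compounds shown here, compound 1 stands as the only value shown as a number; the other two are limits, as the limit of > 50000 nM in this assay, at which 2 of the 3 values shown sit, records. Compound 4, `FC(F)(F)c1ccc(CSc2nc(Nc3ccc(Cl)cc3)c3ccccc3n2)cc1`, differs from compound 1 in one place: 4-chlorophenyl in place of hexyl on a nitrogen on an aromatic ring. The step that bears on this change is an at least 2.0-fold higher number from compound 1 to compound 3 (0.32 log units; beyond the scatter), where a 2-methoxyphenyl replaced the hexyl on a nitrogen on an aromatic ring and the value ran to the limit. In this assay a weakening of at least modest size is therefore expected for compound 4, very possibly again reaching only a limit. The expected value for compound 4 is 55000 nM, within 20000 nM to 150000 nM. For compound 4 this means an expected step of a 2.3-fold higher number from compound 1 to compound 4 (0.36 log units; beyond the scatter).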

Compound 4, half-maximal inhibitory concentration: 14100 nM
For compound 4 the middle estimate is 3.9-fold (0.59 log units) above the measured one, outside the stated range (below it).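

In this assay, an aromatic ring on this nitrogen is not in itself a loss: 4-chlorophenyl in place of hexyl gives a 1.7-fold lower number from compound 1 to compound 4 (0.23 log units; within the scatter). The choice of ring group does matter, as 4-chlorophenyl in place of 2-methoxyphenyl gives an at least 3.5-fold lower number from compound 3 to compound 4 (0.54 log units; beyond the scatter). The (4-chlorophenyl)amino group in place of piperidin-1-yl gives an at least 3.5-fold lower number from compound 2 to compound 4 (0.54 log units; beyond the scatter), and both of these steps start from a limit: the limit of > 50000 nM in this assay, at which 2 of the 4 values shown sit.

The compounds shown leave open whether the difference follows the chlorine or the methoxy group, and a 2-chlorophenyl or 4-methoxyphenyl group would separate the two. Going by these compounds, how a 4-aminophenyl or 4-carboxyphenyl group on this nitrogen would read also remains open.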